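A few compounds are considered here, and "the series" means these few. Any claim that something is new, unique, unknown or untested is made for them only; others in the source may bear on it.

In a functional assay on liver (Rattus norvegicus, strain Sprague-Dawley) for inhibition, with a stated time of 1 h (a lower number here means a stronger inhibitor, a higher number a weaker inhibitor), three compounds with a shared core have been measured. Compound 1 `COc1ccc(C(=O)OCC2Oc3ccc([C@H]4Oc5cc(O)cc(O)c5C(=O)[C@@H]4O)cc3OC2c2ccc(O)c(OC)c2)cc1` gives 21000 nM, compound 2 `COc1cc(C2Oc3cc([C@H]4Oc5cc(O)cc(O)c5C(=O)[C@@H]4O)ccc3OC2COC(=O)c2ccccc2)ccc1O` gives 12700 nM, and compound 3 `COc1cc(C2Oc3cc([C@H]4Oc5cc(O)cc(O)c5C(=O)[C@@H]4O)ccc3OC2COC(=O)c2ccc([N+](=O)[O-])cc2)ccc1O` gives 12600 nM. Compound 3 therefore cannot be separated from either of the other two, as both of its gaps lie within the scatter.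

Compound 4 `COc1cc(C2Oc3cc([C@H]4Oc5cc(O)cc(O)c5C(=O)[C@@H]4O)ccc3OC2COC(=O)c2cccc(Cl)c2)ccc1O` differs from compound 3 at a single place: 3-chlorophenyl in place of 4-nitrophenyl on a carbonyl carbon. In words, this is 3-chlorophenyl in place of 4-nitrophenyl on a carbonyl carbon. Going by the values given here, three measured steps bear on this change, since each swaps a substituent on the same aromatic ring: a 1.7-fold lower number from compound 1 to compound 2 (0.22 log units; within the scatter), a 1.7-fold lower number from compound 1 to compound 3 (0.22 log units; within the scatter) and a 1.0-fold lower number from compound 2 to compound 3 (0.00 log units; within the scatter). All three stay within the scatter. Among the compounds with values here, no measured compound carries chlorine, so the expectation is an extrapolation from these three. No step beyond the scatter is expected in this assay. The expected change is a 1.0-fold higher number from compound 3 to compound 4 (0.01 log units; within the scatter). Compound 4 is estimated at 13000 nM, with an expected range from 7000 nM to 25000 nM.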

Compound 4, half-maximal inhibitory concentration: 14200 nM
Estimate against measurement, compound 4: 1.1-fold (0.04 log units) below; measured number inside the range.
By their numbers in this assay, from the lowest: compounds 3, 2, 4 and 1 (each within the scatter of the next).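

In this assay, three single changes now end in compound 4: 3-chlorophenyl in place of 4-nitrophenyl on the carbonyl carbon (a 1.1-fold higher number from compound 3 to compound 4 (0.05 log units; within the scatter)), the addition of a chloro group to the aromatic ring (a 1.1-fold higher number from compound 2 to compound 4 (0.05 log units; within the scatter)), and 3-chlorophenyl in place of 4-methoxyphenyl on the carbonyl carbon (a 1.5-fold lower number from compound 1 to compound 4 (0.17 log units; within the scatter)). Chlorine is new to this ring and its printed place differs from that of the nitro and methoxy groups, yet none of the three steps leaves the scatter, so the carbonyl carbon has now carried four different aromatic groups without a separable difference. No measurement at hand explains this absence of a separable difference.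

Going by these compounds, whether an amine or a carboxylic acid on this ring would produce a step beyond the scatter remains open. The same holds for a longer chain in place of the ring.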